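The source may hold more compounds than are shown below. What is called first, only, known or untested is meant among the compounds shown, and "the series" means these compounds.

Compound 1 `C/C(=C\CC/C(C)=C/CC[C@@H]1[C@@]2(C)CCC(=O)C(C)(C)[C@H]2CC[C@@]1(C)O)CC/C=C(\C)C(=O)OCc1cn(-c2ccc([N+](=O)[O-])cc2)nn1` carries a 4-nitrophenyl group on an aromatic nitrogen of a five-membered aromatic ring with 3 nitrogen. In a functional assay on DU-145 cells (Homo sapiens) for antiproliferative activity, read by MTT assay, with a stated time of 48 h (a lower number here means a stronger inhibitor, a higher number a weaker inhibitor), compound 1 gives > 150000 nM, which is a limit of the assay rather than a measured number (the limit of > 150000 nM in this assay, at which 1 of the 2 values shown sits). Compound 2 `COc1ccc(-n2cc(COC(=O)/C(C)=C/CC/C(C)=C/CC/C(C)=C/CC[C@@H]3[C@@]4(C)CCC(=O)C(C)(C)[C@H]4CC[C@@]3(C)O)nn2)cc1` has a methoxy in place of nitro on an aromatic carbon, and in this assay compound 2 gives 135000 nM. The step of an at least 1.1-fold lower number from compound 1 to compound 2 (0.04 log units; that floor lies within the scatter) is small and lies within the scatter, so both compounds count as very weak inhibitors. Compound 3 `C/C(=C\CC/C(C)=C/CC[C@@H]1[C@@]2(C)CCC(=O)C(C)(C)[C@H]2CC[C@@]1(C)O)CC/C=C(\C)C(=O)OCc1cn(-c2ccccc2F)nn1` has not yet been measured; it differs from compound 1 by 2-fluorophenyl in place of 4-nitrophenyl on an aromatic nitrogen. Within the data shown here, because the only comparable change, an at least 1.1-fold lower number from compound 1 to compound 2 (0.04 log units; that floor lies within the scatter), stayed within the scatter, the step expected in this assay is a number no higher from compound 1 to compound 3 (the limit leaves the size open), with no clear direction. Compound 3 is therefore estimated at 150000 nM, between 70000 nM and 320000 nM, and a limit may well be reported again.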

Compound 3, half-maximal inhibitory concentration: > 150000 nM
Compound 3: a limit, no number; the forecaster's own chance of this, stated with the estimate: 55%; the middle value lies on the limit itself.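

In this assay, compound 3 gives a limit of the assay and not a number, as compound 1 does, so the step between these two cannot be read. Set against the measured compound 2, the change to 2-fluorophenyl gives an at least 1.1-fold higher number from compound 2 to compound 3 (0.04 log units; that floor lies within the scatter), so a third group on this aromatic nitrogen, now one carrying fluorine, does not separate itself from the 4-methoxyphenyl compound. All three phenyl groups tried at this position leave the compounds very weak, and the readings crowd against the top of the range: the limit of > 150000 nM in this assay, at which 2 of the 3 values shown sit.

As far as these compounds go, what remains open is whether this position can give a clearly stronger inhibitor at all. An amine or a carboxylic acid on the phenyl ring, or a longer chain in place of that ring, could answer this, and the compounds shown say nothing about either.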